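Cyano substituent on the benzyl ring: expected whole-animal inhibition

The source may hold more compounds than are shown below. What is called first, only, known or untested is meant among the compounds shown, and "the series" means these compounds.

Measured compounds:
compound 1, `Brc1ccccc1COc1nc2ccccc2s1`, 75.6%
compound 2, `c1ccc(COc2nc3ccccc3s2)cc1`, 68.8%
compound 3, `Fc1cccc(COc2nc3ccccc3s2)c1`, 86.8%

In a functional assay on the whole organism with Mus musculus as the target, with a stated time of 1 h, at a dose of 100 mg/kg by the intraperitoneal route (on this read-out lower numbers stand for less inhibition and higher numbers for more inhibition at the one dose given (going by the name of the read-out)), compound 2 gives the lowest of the three numbers, 68.8%. Compound 1 sits nearest, a number 6.8 percentage points lower from compound 1 to compound 2 (within the scatter), so these two cannot be told apart. Compound 3 lies furthest away, a number 18 percentage points higher from compound 2 to compound 3 (beyond the scatter).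

Compound 4, `N#Cc1ccc(COc2nc3ccccc3s2)cc1`, differs from compound 2 by cyano in place of hydrogen on an aromatic carbon. Among the compounds with values here, two measured steps bear on this change, since each adds or removes a single group on the same ring of the shared core: the step of a number 6.8 percentage points lower from compound 1 to compound 2 (within the scatter), and the step of a number 18 percentage points higher from compound 2 to compound 3 (beyond the scatter). One of them is within the scatter, the other is modest and upward. Within the data shown here, no measured step concerns a cyano group, so the expectation is loose: a small rise, or no change beyond the scatter, in this assay.

Compound 4 is therefore expected to show 76%, with a range from 60% to 92%, which amounts to an estimated step of a number 7.2 percentage points higher from compound 2 to compound 4 (within the scatter).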

Compound 4, a percentage reported as inhibition, in the whole organism at one dose (the size of the read-out at that dose, not a potency): 12.7%
Beside the measured number, compound 4's estimate is 63.3 percentage points above it; measured number outside the range, below it.
By their numbers in this assay, from the lowest: compound 4; then compounds 2 and 1 (each within the scatter of the next); then compound 3.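

In this assay cyano in place of hydrogen, para to a large group, gives a number 56.1 percentage points lower from compound 2 to compound 4 (beyond the scatter) and so shows that one added group on this ring can take away most of the inhibition. Neither a number 6.8 percentage points lower from compound 1 to compound 2 (within the scatter) nor a number 18 percentage points higher from compound 2 to compound 3 (beyond the scatter) pointed that way, as those steps stayed within the scatter or went upward. No measurement given here bears on the cause of this large drop.

Whether the loss follows cyano itself or any group at this place stays open, as compound 4 is the only compound shown with a group para to a large group. A carboxylic acid or an amine at that place, or cyano elsewhere on the ring, would tell these two readings apart.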